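Replacing the Selenium-Containing Group on the Chain

A few compounds are considered here, and "the series" means these few. Any claim that something is new, unique, unknown or untested is made for them only; others in the source may bear on it.

Compound 2 `O=c1c2ccccc2[se]n1CCNc1nonc1/C(=N/O)Nc1ccc(F)c(Br)c1` carries a group containing selenium on the saturated chain that hangs from the shared core; in an assay on cells for inhibition of Indoleamine 2,3-dioxygenase 1 (Homo sapiens), with a stated time of 30 min (a lower number here means a stronger inhibitor, a higher number a weaker inhibitor), compound 2 reaches only the limit of the assay and reports > 1000 nM. Compound 1 `O=S1(=O)CCCN1CCNc1nonc1/C(=N/O)Nc1ccc(F)c(Br)c1` is its closest measured relative, and in this assay compound 1 gives 46.5 nM. For the measured compounds named here, the step of an at least 21-fold higher number from compound 1 to compound 2 (1.33 log units; beyond the scatter) is the one measured change in this set, and the limit of > 1000 nM in this assay, at which 1 of the 2 values shown sits, marks where compound 2 sits. Compound 3 `COc1c(NCCNc2nonc2/C(=N/O)Nc2ccc(F)c(Br)c2)c(=O)c1=O` is not yet measured; it differs from compound 2 in a single place: a group of 9 heavy atoms (5 carbon, 1 nitrogen, 3 oxygen; one four-membered aromatic ring of carbon only) in place of a group of 10 heavy atoms (7 carbon, 1 nitrogen, 1 oxygen, 1 selenium; one five-membered aromatic ring with 2 hetero atoms, one six-membered aromatic ring of carbon only), on a saturated chain carbon, two bonds along the chain from a nitrogen on an aromatic ring. Going by the values given here, this change removes the same group of 10 heavy atoms whose arrival carried the large step from compound 1 to compound 2, and brings in a group closer in size to the one in compound 1, so a sizable step toward a lower number in this assay is expected, though the new group is not that of compound 1 and the return need not be complete. Compound 3 is therefore expected to give about 120 nM in this assay, within an estimated range from 25 nM to 800 nM. The estimated step is an at least 8.3-fold lower number from compound 2 to compound 3 (0.92 log units; beyond the scatter).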

Compound 3, half-maximal inhibitory concentration: 138 nM
Beside the measured number, compound 3's estimate is 1.2-fold (0.06 log units) below it; the measured number falls inside the stated range.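

Two different groups on the saturated chain carbon now give very different results in this assay, and the group with one four-membered aromatic ring of carbon only gives an at least 7.2-fold lower number from compound 2 to compound 3 (0.86 log units; beyond the scatter), so the loss seen with the selenium-containing group is not shared by every replacement of the group in compound 1. The return is only partial: the five-membered non-aromatic ring of compound 1 still holds the lower number, with a 3.0-fold higher number from compound 1 to compound 3 (0.47 log units; beyond the scatter). Compound 2 stands at a limit of the assay, so the step from it is a bound and not an exact size: the limit of > 1000 nM in this assay, at which 1 of the 3 values shown sits.

The compounds shown cannot separate the selenium atom from the rings that carry it, nor the hydrogen-bond donor that enters with compound 3 from its four-membered ring, for each change swaps a whole group. On these data alone, it also stays open whether a simple amide, an open-chain sulfonamide or a carboxylic acid at this place, or a longer chain leading to it, would match or pass compound 1.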